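The source may hold more compounds than are shown below. What is called first, only, known or untested is meant among the compounds shown, and "the series" means these compounds.

Measured compounds:
- Compound 1 `O=C(Nc1ccc(Cl)cc1)c1c(NO)cc(-c2cccs2)oc1=O`; in an ADME assay on Huh-7 cells (Homo sapiens) for cytotoxicity, with a stated time of 3 days (on this read-out higher numbers stand for lower toxicity in this test and lower numbers for higher toxicity in this test), compound 1 gives > 20000 nM, which is a limit of the assay.
- Compound 2 `O=C(Nc1ccc(Br)cc1)c1c(NO)cc(-c2cccs2)oc1=O`; compound 2 gives > 20000 nM, again a limit.
- Compound 3 `O=C(Nc1ccc(Cl)cc1)c1c(NCCO)cc(-c2ccc(Br)cc2)oc1=O`; compound 3 gives > 20000 nM, likewise a limit.

Compound 1 and compound 2 differ in a single place: bromo in place of chloro on an aromatic carbon. The step that the two limits leave unreadable from compound 1 to compound 2 cannot be read because both values sit at the limit of > 20000 nM in this assay, at which 3 of the 3 values shown sit. Compound 3 carries the same kind of anilide but a different core; the difference between the two cores is not broken down here. Compound 4 `O=C(Nc1ccc(Br)cc1)c1c(NCCO)cc(-c2ccc(Br)cc2)oc1=O`, not yet measured, relates to compound 3 as compound 2 relates to compound 1: bromo in place of chloro on an aromatic carbon, the same change at the same place, the second time it occurs among these compounds. Resting on the unreadable a step that the two limits leave unreadable from compound 1 to compound 2 and on (the limit of > 20000 nM in this assay, at which 3 of the 3 values shown sit), the estimated step is a step that the limit leaves unreadable from compound 3 to compound 4. Compound 4 is expected to give 30000 nM in this assay, within 15000 nM to 100000 nM, and most probably to be reported only as a limit once more.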

Compound 4, half-maximal cytotoxic concentration: > 20000 nM
Compound 4: only a limit was reported (the forecaster's own chance of this, stated with the estimate: 85%); the middle value is on the limit's open side.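

In this assay compound 4 gives > 20000 nM, which is again a limit of the assay. No size can be read for the step between compound 3 and compound 4, because both values are limits: the limit of > 20000 nM in this assay, at which 4 of the 4 values shown sit. The compounds shown leave open the actual half-maximal cytotoxic concentration of each compound, and whether bromo in place of chloro alters it.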